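The compounds below may be only part of what the source reports. "The series", "measured", "known", "first", "only" and "open" are said of these compounds alone.

Working notes on the nitropyrrole hydrazide series.

Compound 1 `O=C(NNC(=S)NCc1ccccc1)c1cc([N+](=O)[O-])c[nH]1` was measured in an ADME assay on Vero cells (Chlorocebus sabaeus) for cytotoxicity, read by MTT assay, with a stated time of 72 h (on this read-out higher numbers stand for weaker inhibition and lower numbers for stronger inhibition), and gives 397000 nM. Two further compounds of the series share the same read-out: compound 2 `COc1ccc(NC(=O)NNC(=O)c2cc([N+](=O)[O-])cn2C)cc1` gives 328000 nM, and compound 3 `Cn1cc([N+](=O)[O-])cc1C(=O)NNC(=O)Nc1ccc(Br)cc1` gives 602000 nM. The only single-point step among these measured compounds runs a 1.8-fold higher number from compound 2 to compound 3 (0.26 log units; within the scatter). Compound 1 sits second highest of the three numbers; its gap to compound 2 and its gap to compound 3 both lie within the scatter, so the three values show no order that can be read.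

Compound 4 `O=C(NNC(=S)Nc1ccc(Cl)cc1)c1cc([N+](=O)[O-])c[nH]1` is not yet measured. Relative to compound 1 it differs as follows: 4-chlorophenyl in place of benzyl on an amide-type nitrogen. Within the data shown here, no measured step covers this exchange of benzyl for 4-chlorophenyl on the thiocarbonyl-bearing nitrogen. Among the measured compounds shown here, the one step that is known, the swap of methoxy for bromo in the pair from compound 2 to compound 3, concerns a different position and stayed within the scatter, and all three measured values cluster closely. On that basis no step beyond the scatter is expected in this assay for compound 4, and the expected step is a 1.0-fold higher number from compound 1 to compound 4 (0.00 log units; within the scatter). Compound 4 is therefore estimated at 400000 nM, with a range from 200000 nM to 800000 nM, pending the measurement.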

Compound 4, half-maximal inhibitory concentration: 191000 nM
For compound 4 the middle estimate is 2.1-fold (0.32 log units) above the measured one, outside the stated range (below it).
By their numbers in this assay, from the lowest: compounds 4, 2, 1 and 3 (each within the scatter of the next, the first and the last beyond it).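

In this assay the exchange of benzyl for 4-chlorophenyl on the amide-type nitrogen whose other neighbour is the thiocarbonyl carbon gives a 2.1-fold lower number from compound 1 to compound 4 (0.32 log units; beyond the scatter), a modest step but the only one among these compounds that lies beyond the scatter, whereas a 1.8-fold higher number from compound 2 to compound 3 (0.26 log units; within the scatter) does not clear it. This position therefore responds to a change of group even though leaving and entering groups share the same heavy-atom count, one six-membered aromatic ring of carbon only, no hydrogen-bond donors or acceptors and no net charge, the counted difference being one carbon given up and one chlorine taken on. No measurement at hand accounts for the step.

The compounds shown leave open whether the step belongs to the chlorine or to the loss of the carbon that holds the ring away from the nitrogen in benzyl, a question that plain phenyl on this nitrogen would separate. Also open, from the compounds shown here alone, is how a longer chain ending in phenyl, or a group carrying an amine or a carboxylic acid, would read at this position.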